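Compound 4: a difluorophenyl amide on the ethylpiperazinyl core

The compounds below may be only part of what the source reports. "The series", "measured", "known", "first", "only" and "open" are said of these compounds alone.

Measured so far in a functional assay on MCF7 cells (Homo sapiens) for antiproliferative activity, read by MTT assay, with a stated time of 72 h; a lower number here means a stronger inhibitor, a higher number a weaker inhibitor:
compound 1 `CNc1cc(C)c2cc(NC(=O)c3ccc(Cl)c(Cl)c3)ccc2n1` — 2520 nM
compound 2 `CCN1CCN(c2cc(C)c3cc(NC(=O)c4cccnc4)ccc3n2)CC1` — 26600 nM
compound 3 `CCNc1cc(C)c2cc(NC(=O)c3ccc(Cl)c(Cl)c3)ccc2n1` — 48600 nM

Compound 2 has the second highest of the three numbers; its nearest neighbour is compound 3, a gap within the scatter, and its furthest is compound 1, whose number is lower by a gap beyond the scatter. Compound 1 and compound 2 differ in more than one place, so their values alone say nothing about any single change.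

Compound 4 `CCN1CCN(c2cc(C)c3cc(NC(=O)c4ccc(F)c(F)c4)ccc3n2)CC1` differs from compound 2 in one place: 3,4-difluorophenyl in place of pyridin-3-yl on a carbonyl carbon.

For the measured compounds named here, the only measured step, a 19-fold higher number from compound 1 to compound 3 (1.29 log units; beyond the scatter), concerns a different change and does not bear on this one. Going by the values given here, no measured pair isolates the swap of an aromatic ring on the carbonyl carbon, so the direction and size of the step in this assay are open. The estimate therefore stays near compound 2 with a wide range, and the expected step of a 1.8-fold lower number from compound 2 to compound 4 (0.25 log units; within the scatter) is modest and uncertain in direction. Compound 4 is estimated at 15000 nM, between 3000 nM and 60000 nM.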

Compound 4, half-maximal inhibitory concentration: 5230 nM
Compound 4: the middle estimate sits 2.9-fold (0.46 log units) above what was measured; measured number inside the range.
By their numbers in this assay, from the lowest: compound 1; then compound 4; then compounds 2 and 3 (each within the scatter of the next).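

In this assay, for the compounds shown here, the swap of pyridin-3-yl for 3,4-difluorophenyl on the carbonyl carbon gives a 5.1-fold lower number from compound 2 to compound 4 (0.71 log units; beyond the scatter) and is the first measured step at this position. It shows that the aromatic ring on this carbonyl carbon can shift the number on the ethylpiperazinyl core by more than the usual scatter, and here the carbon-only ring with two fluorines gives the lower number. Nothing measured on these compounds explains the size or direction of this step. The change removes the ring nitrogen and adds both fluorines at once, so the step cannot be divided between those parts. Going by these compounds, whether a plain phenyl ring or a 4-fluorophenyl group on the same carbonyl carbon would fall nearer compound 2 or compound 4 stays open.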